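The compounds below may be only part of what the source reports. "The series", "measured", "known", "first", "only" and "open" are said of these compounds alone.

Measured in a functional assay on A549 cells (Homo sapiens) for antiproliferative activity, with a stated time of 72 h (a higher number here means a weaker inhibitor, a lower number a stronger inhibitor), so far
- compound 1 `O=C(COc1ccc(CNC2CC=C(c3c[nH]c4ccc(F)cc34)CC2)c(F)c1)NO` gives 304 nM
- compound 2 `Cc1[nH]c2ccccc2c1C1=CCC(NCc2ccc(OCC(=O)NO)cc2)CC1` gives 187 nM
- compound 3 `Cc1[nH]c2cccc(F)c2c1C1=CCC(NCc2ccc(OCC(=O)NO)cc2F)CC1` gives 244 nM

Compound 3 has the second highest of the three numbers, and its gaps to both other compounds lie within the scatter. Compound 1 is its nearest neighbour and compound 2 its furthest. The three numbers therefore give no ranking of these compounds.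

Compound 4 `Cc1[nH]c2ccccc2c1C1=CCC(NCc2ccc(OCC(=O)NO)cc2F)CC1` is compound 3 with hydrogen in place of fluoro on an aromatic carbon. Among the measured compounds shown here, no step between measured compounds isolates this change, so the data offer no direct measure of it. For the measured compounds named here, the only guide is the narrow spread of the series, with compound 3 at 244 nM and compound 2 at 187 nM, a gap within the scatter. No change beyond the scatter is therefore expected in this assay, and no direction can be called with confidence. The expected move is a 1.1-fold lower number from compound 3 to compound 4 (0.05 log units; within the scatter), which stays within the scatter. The estimated value for compound 4 is 215 nM, with an expected range of 120 nM to 380 nM.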

Compound 4, half-maximal inhibitory concentration: 130 nM
Compound 4: the middle estimate sits 1.7-fold (0.22 log units) above what was measured, and the stated range covers the measured number.
By their numbers in this assay, from the lowest: compounds 4, 2, 3 and 1 (each within the scatter of the next, the first and the last beyond it).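

In this assay, among the compounds shown here, hydrogen in place of fluoro on this aromatic carbon, ortho to a fused ring, gives a 1.9-fold lower number from compound 3 to compound 4 (0.27 log units; within the scatter), the first direct reading of this position, and it shows no change that can be told from the scatter. The other fluoro swap on an aromatic carbon, a 1.4-fold lower number from compound 2 to compound 4 (0.16 log units; within the scatter), also stays within the scatter, so neither single fluoro step separates its pair. For the compounds shown here, the one step beyond the scatter is a 2.3-fold lower number from compound 1 to compound 4 (0.37 log units; beyond the scatter), a modest move with 2-methyl-1H-indol-3-yl in place of 5-fluoro-1H-indol-3-yl.

Nothing available explains any of these steps. As far as these compounds go, whether chloro or methoxy on this aromatic carbon would give a step beyond the scatter in this assay remains open.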